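Replacing Benzyl with Phenoxycarbonyl on the Carbamate Nitrogen

This account rests on a few compounds, and the source may have more. Where it says the series, first, only, none or still open, it means among the compounds named here.

Compound 1 `CC(C)=CCC/C(C)=C/CC/C(C)=C/CC[C@]1(C)CCc2c(C)c(OC(=O)Nc3ccccc3)c(C)c(C)c2O1` in a functional assay on MDA-MB-231 cells (Homo sapiens) for antiproliferative activity, read by MTT assay, with a stated time of 96 h (on this read-out higher numbers stand for weaker inhibition and lower numbers for stronger inhibition), gives > 10000 nM, which is a limit of the assay.
Compound 2 `CC(C)=CCC/C(C)=C/CC/C(C)=C/CC[C@]1(C)CCc2c(C)c(O)c(C)c(C)c2O1` in this assay gives > 10000 nM, also a limit.
Compound 3 `CC(C)=CCC/C(C)=C/CC/C(C)=C/CC[C@]1(C)CCc2c(C)c(OC(=O)NCc3ccccc3)c(C)c(C)c2O1` in this assay gives 7200 nM.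

For the measured compounds named here, compound 3 carries the only actual number among the three measured compounds; the other two sit at the limit (the limit of > 10000 nM in this assay, at which 2 of the 3 values shown sit). The change from compound 3 to compound 4 `CC(C)=CCC/C(C)=C/CC/C(C)=C/CC[C@]1(C)CCc2c(C)c(OC(=O)NC(=O)Oc3ccccc3)c(C)c(C)c2O1` is phenoxycarbonyl in place of benzyl on an amide-type nitrogen. The closest measured comparison is the step of an at least 1.3-fold lower number from compound 1 to compound 3 (0.14 log units; that floor lies within the scatter), where a benzyl in place of phenyl on the same amide-type nitrogen moved the value from a limit to a number, and the step of an at least 1.3-fold lower number from compound 2 to compound 3 (0.14 log units; that floor lies within the scatter) shows that the whole benzylcarbamoyl group did the same relative to the free hydroxyl. Phenoxycarbonyl on the nitrogen resembles compound 1 more than compound 3 in removing the benzyl, so a return toward the limit is expected. The expected step of a 1.5-fold higher number from compound 3 to compound 4 (0.18 log units; within the scatter) is therefore toward a higher number. Compound 4 is estimated at 11000 nM, within 4000 nM to 30000 nM.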

Compound 4, half-maximal inhibitory concentration: > 10000 nM
Compound 4 ended at the assay's limit (the forecaster's own chance of this, stated with the estimate: 60%); the middle value is on the limit's open side.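

Phenoxycarbonyl in place of benzyl on the amide-type nitrogen gives an at least 1.3-fold higher number from compound 3 to compound 4 (0.14 log units; that floor lies within the scatter). In this assay, compound 4 gives > 10000 nM, which is a limit of the assay and not a number. Phenyl and phenoxycarbonyl on this nitrogen both leave the value at that limit, so a carbamoyl group on the oxygen does not bring a number by itself, and compound 3 is still the only one of the four with an actual number: the limit of > 10000 nM in this assay, at which 3 of the 4 values shown sit.

The steps from compound 1 to compound 4 and from compound 2 to compound 4 join two limits and cannot be read. Going by these compounds, whether a phenylethyl group, with a longer chain to the ring, or a small methyl group on the same nitrogen would bring the value below that of compound 3 stays open.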